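The source may hold more compounds than are shown below. What is called first, only, known or untested is meant among the compounds shown, and "the series" means these compounds.

Measured in a functional assay on HCT-116 cells (Homo sapiens) for antiproliferative activity, read by sulforhodamine B assay, with a stated time of 72 h; a lower number here means a stronger inhibitor, a higher number a weaker inhibitor:
compound 1 `Cn1ncc(Cl)c1-c1cc(C(=O)N[C@@H]2CN[C@H](CCN3CCCCC3)C[C@H]2c2ccc(Cl)c(Cl)c2)oc1Cl`: 1020 nM
compound 2 `C=CC[C@@H]1C[C@@H](c2ccc(Cl)c(Cl)c2)[C@H](NC(=O)c2cc(-c3c(Cl)cnn3C)c(Cl)o2)CN1`: 780 nM
compound 3 `CN(C)CC[C@@H]1C[C@@H](c2ccc(Cl)c(Cl)c2)[C@H](NC(=O)c2cc(-c3c(Cl)cnn3C)c(Cl)o2)CN1`: 1710 nM

In this assay compound 3 gives 1710 nM. Its nearest neighbour in the set is reached by a 1.7-fold higher number from compound 1 to compound 3 (0.22 log units; within the scatter). Going by the values given here, its furthest is reached by a 2.2-fold higher number from compound 2 to compound 3 (0.34 log units; beyond the scatter), the only step here beyond the scatter, and a modest one.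

Compound 4 `Cn1ncc(Cl)c1-c1cc(C(=O)N[C@@H]2CN[C@H](CC(=O)NC3CC3)C[C@H]2c2ccc(Cl)c(Cl)c2)oc1Cl` keeps the shared core and differs in one group: cyclopropylcarbamoyl in place of (dimethylamino)methyl on a saturated chain carbon bound to a saturated ring carbon. This places cyclopropylcarbamoyl in place of (dimethylamino)methyl on a saturated chain carbon bound to a saturated ring carbon.

The measured steps that bear on this change are all side-chain changes in the same region: a 1.3-fold lower number from compound 1 to compound 2 (0.12 log units; within the scatter), a 1.7-fold higher number from compound 1 to compound 3 (0.22 log units; within the scatter) and a 2.2-fold higher number from compound 2 to compound 3 (0.34 log units; beyond the scatter). All three are small, although the groups exchanged differ widely. Among the compounds with values here, none of the measured compounds carries cyclopropylcarbamoyl, so the data offer no direct precedent for it.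

In this assay, no step beyond the scatter is therefore expected, with a slight lean towards a lower number. That lean rests only on compound 2 at 780 nM. The expected change is a 1.6-fold lower number from compound 3 to compound 4 (0.19 log units; within the scatter). For compound 4 the estimated value is 1100 nM, with an expected range of 450 nM to 2700 nM.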

Compound 4, half-maximal inhibitory concentration: 740 nM
Estimate against measurement, compound 4: 1.5-fold (0.17 log units) above; low and high end bracket the measured number.
By their numbers in this assay, from the lowest: compounds 4, 2, 1 and 3 (each within the scatter of the next, the first and the last beyond it).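

In this assay the exchange of (dimethylamino)methyl for cyclopropylcarbamoyl on a saturated chain carbon bound to a saturated ring carbon gives a 2.3-fold lower number from compound 3 to compound 4 (0.36 log units; beyond the scatter) as a modest step, which shows that a side chain carrying a carbonyl, an amide hydrogen and a three-membered ring is accepted at this place with no loss against compound 3. The new group also stays level with the other two side chains, with a 1.1-fold lower number from compound 2 to compound 4 (0.02 log units; within the scatter) and a 1.4-fold lower number from compound 1 to compound 4 (0.14 log units; within the scatter) both inside the scatter, so among these compounds an amine in this side chain is not needed to reach this level of activity in these cells. Nothing shown here accounts for the size of the step from the dimethylamino side chain to the amide one.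

Going by these compounds, whether the amide hydrogen or the cyclopropyl ring matters stays open, and a methylated amide nitrogen or a plain primary carboxamide at this place would address that. On these data alone, a carboxylic acid or a longer chain ending in the same amide is also absent from these compounds, so how far this tolerance extends remains unknown.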